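The compounds below may be only part of what the source reports. "The series", "measured", "known", "first", "only" and "open" are said of these compounds alone.

Working notes on the series. Compound 1 `O=C(/C=C/c1cccc(NC(=O)c2ccccc2Cl)c1)c1nc2ccccc2[nH]1` and compound 2 `O=C(Nc1cccc(/C=C/C(=O)c2nc3ccccc3[nH]2)c1)c1cccc(C(F)(F)F)c1` share one core and differ only in the aryl group on the amide carbonyl carbon. In a functional assay on HCT-116 cells (Homo sapiens) for antiproliferative activity, read by MTT assay, with a stated time of 48 h (a higher number here means a weaker inhibitor, a lower number a stronger inhibitor), compound 1 gives 1280 nM and compound 2 gives 3360 nM. Among the compounds with values here, the single measured step, a 2.6-fold higher number from compound 1 to compound 2 (0.42 log units; beyond the scatter), is the only comparison available so far. On the two numbers in hand compound 2 stands highest, with compound 1 nearest.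

Compound 3 `O=C(Nc1cccc(/C=C/C(=O)c2nc3ccccc3[nH]2)c1)c1cc(Cl)cc(Cl)c1` continues at the same position: 3,5-dichlorophenyl in place of 3-(trifluoromethyl)phenyl on a carbonyl carbon. Within the data shown here, the one measured step that bears on this exchange is the aryl swap on the same carbonyl carbon, a 2.6-fold higher number from compound 1 to compound 2 (0.42 log units; beyond the scatter), which was modest in size. Nothing in the set shows how two chlorines on one ring behave against a single trifluoromethyl, so the expectation leans on that step alone and stays close to compound 2. The step from compound 2 to compound 3 in this assay is expected to be small, a 1.3-fold lower number from compound 2 to compound 3 (0.13 log units; within the scatter), in either direction or none beyond the scatter. Compound 3 is accordingly estimated at 2500 nM, within 1000 nM to 6500 nM.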

Compound 3, half-maximal inhibitory concentration: 1650 nM
For compound 3 the middle estimate is 1.5-fold (0.18 log units) above the measured one; the measured number falls inside the stated range.
By their numbers in this assay, from the lowest: compounds 1 and 3 (each within the scatter of the next); then compound 2.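

In this assay, 3,5-dichlorophenyl in place of 3-(trifluoromethyl)phenyl on the carbonyl carbon whose other neighbour is the amide-type nitrogen gives a 2.0-fold lower number from compound 2 to compound 3 (0.31 log units; beyond the scatter), so a second aryl exchange at this place also moves the number by a modest but readable amount. Set against the 2-chlorophenyl group, the same ring gives a 1.3-fold higher number from compound 1 to compound 3 (0.11 log units; within the scatter), which means that the two chlorine-bearing aryl groups are not separated in this assay, whereas the 3-(trifluoromethyl)phenyl group of compound 2 stands apart from both with the highest number of the three. Nothing available explains these differences or accounts for the two chlorine-bearing rings reading alike.

Going by these compounds, all three compounds carry an aryl group bearing chlorine or trifluoromethyl on this carbonyl carbon, so the response to a ring carrying a methoxy group, an amine or a carboxylic acid remains open. Also open, on these data alone, is whether the order seen here holds on any cell line other than this one.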